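Chloro Steps Across Two Hydrazone Cores

A few compounds are considered here, and "the series" means these few. Any claim that something is new, unique, unknown or untested is made for them only; others in the source may bear on it.

Compound 1 `CC(=O)/C(=N\Nc1ccccc1)N(C)c1cccc(Cl)c1` and compound 2 `CC(=O)/C(=N\Nc1ccccc1Cl)N(C)c1cccc(Cl)c1` share one core. In an assay on isolated protein for binding affinity to corticotropin-releasing factor receptor 1 (Homo sapiens) (a lower number here means a stronger inhibitor, a higher number a weaker inhibitor), compound 1 gives > 10000 nM, which is a limit of the assay and not a number. Compound 2 gives > 10000 nM in this assay, again a limit. The change between them, (chloro in place of hydrogen on an aromatic carbon), therefore yields a step that the two limits leave unreadable from compound 1 to compound 2 because of the limit of > 10000 nM in this assay, at which 2 of the 3 values shown sit. Compound 3 `CC(=O)/C(=N\c1ccccc1)NNc1ccccc1C` rests on a different core; how the two cores differ is not broken down here. In this assay, among the compounds with values here, compound 3 gives 526 nM, the only number so far. Compound 4 `CC(=O)/C(=N\c1ccc(Cl)cc1)NNc1ccccc1C` differs from compound 3 by chloro in place of hydrogen on an aromatic carbon, the same kind of change, though here the chloro sits para to a large group rather than ortho. With the earlier step unreadable, the expected step from compound 3 to compound 4 is a 1.3-fold lower number from compound 3 to compound 4 (0.12 log units; within the scatter), resting only on compound 3 at 526 nM. Compound 4 is thus estimated at 400 nM, between 100 nM and 2000 nM.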

Compound 4, inhibition constant: 1830 nM
Beside the measured number, compound 4's estimate is 4.6-fold (0.66 log units) below it; the measured number falls inside the stated range.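

On the core of compound 3, the chloro change gives a 3.5-fold higher number from compound 3 to compound 4 (0.54 log units; beyond the scatter) in this assay, so on this core 4-chlorophenyl in place of phenyl goes with weaker binding. The same change on the other core cannot be read, so nothing shows whether this result carries from one core to the other: the limit of > 10000 nM in this assay, at which 2 of the 4 values shown sit. A single readable step on a single core therefore sets no rule for the series.

As far as these compounds go, it remains open how the core of compound 3 would respond to a different group at this place on the ring, such as a methoxy, an amine or a carboxylic acid. From the compounds shown here alone, it is also open whether any such group would move the number in the opposite direction from chloro.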